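The source may hold more compounds than are shown below. What is called first, only, known or untested is meant among the compounds shown, and "the series" means these compounds.

Measured compounds:
Compound 1, `Cc1cc(-n2cc(C(=O)Nc3cc(F)cc(F)c3)c(=O)c3ccc(N(C)C)nc32)ccc1OCCCCCCC[N+]12CCN(CC1)CC2`, gives 20.8%.
Compound 2, `Cc1cc(-n2cc(C(=O)Nc3cc(F)cc(F)c3)c(=O)c3ccc(N(C)C)nc32)ccc1OCCCCCCC[N+]1(C)CCCC1`, gives 35.9%.
Compound 3, `CN(C)c1ccc2c(=O)c(C(=O)Nc3cc(F)cc(F)c3)cn(-c3ccc(OCCCCCCC[N+]4(C)CCCC4)c(Cl)c3)c2n1`, gives 2.59%.

All three were tested in an assay on LX2 cells for inhibition of COL1A1 promoter (Homo sapiens), read by a luciferase reporter, with a stated time of 24 h, tested at 50 uM; on this read-out higher numbers stand for a stronger effect at the one concentration tested and lower numbers for a weaker effect. Among them compound 2 stands highest, with compound 1 next, a step of a number 15.1 percentage points higher from compound 1 to compound 2 (beyond the scatter), and compound 3 furthest away, a step of a number 33.3 percentage points lower from compound 2 to compound 3 (beyond the scatter).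

The compound not yet measured is compound 4, `Cc1cc(-n2cc(C(=O)Nc3cc(F)cc(F)c3)c(=O)c3ccc(N(C)C)nc32)ccc1OCCCCCCC[n+]1ccccc1`. It differs from compound 2 in one place: a group of 6 heavy atoms (5 carbon, 1 nitrogen; one six-membered aromatic ring with 1 hetero atom) in place of a group of 6 heavy atoms (5 carbon, 1 nitrogen; one five-membered non-aromatic ring with 1 hetero atom), on a saturated chain carbon, seven bonds along the chain from an oxygen on an aromatic ring. The charged group at the end of the chain is thus replaced by another charged group of the same size, but built as a six-membered aromatic ring rather than a five-membered non-aromatic one.

Going by the values given here, only one measured step bears on this: the step of a number 15.1 percentage points higher from compound 1 to compound 2 (beyond the scatter), which also altered the charged group at the end of the chain and moved the read-out modestly. The step of a number 33.3 percentage points lower from compound 2 to compound 3 (beyond the scatter) concerns a different position and says nothing about the chain end. Among the compounds with values here, since a change at this site has already shifted the number modestly, a shift of similar size in either direction is plausible here; with no closer precedent, the expectation is a small decrease, a number 7.9 percentage points lower from compound 2 to compound 4 (within the scatter). Compound 4 is therefore estimated at 28%, within a range from 10% to 46%.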

Compound 4, a percentage reported as inhibition, at one concentration (the size of the read-out at that concentration, not a potency): 55%
For compound 4 the middle estimate is 27 percentage points below the measured one; the whole stated range lies below it.
By their numbers in this assay, from the lowest: compound 3; then compound 1; then compound 2; then compound 4.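

In this assay, putting the six-membered aromatic ring with 1 hetero atom at the end of the chain in place of the five-membered non-aromatic ring gives a number 19.1 percentage points higher from compound 2 to compound 4 (beyond the scatter), although both groups have 6 heavy atoms (5 carbon, 1 nitrogen), 0 hydrogen-bond donors, 0 hydrogen-bond acceptors and a net charge of +1, so at this position the read-out differs even when all of these counts match. Against the larger group of 8 heavy atoms with 2 six-membered non-aromatic rings, the same aromatic ring gives a number 34.2 percentage points higher from compound 1 to compound 4 (beyond the scatter), which shows that a change at the chain end can move this read-out by a large step, where the earlier compounds had shown only a modest one. Nothing available explains why the aromatic ring gives the higher number.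

On these data alone, it remains open whether the higher number belongs to aromatic rings in general, which a methyl group on the same ring, an imidazolium ring or a plain piperidine amine at the chain end would help to test. As far as these compounds go, a longer chain carrying this aromatic ring is also open, as is whether the higher number at this one concentration would carry over to a measured potency.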